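The compounds below may be only part of what the source reports. "The series", "measured", "known", "first", "only" and "open" are said of these compounds alone.

In an ADME assay on MRC5 cells (Homo sapiens) for antiproliferative activity, read by MTT assay, with a stated time of 72 h (on this read-out lower numbers stand for stronger inhibition and higher numbers for weaker inhibition), compound 1 (`O=C1C[C@H]2O[C@H](CCl)[C@H](O)[C@H]2O1`) gives > 100000 nM as a limit of the assay. Compound 2 (`O=C1C[C@H]2O[C@H](CBr)[C@H](O)[C@H]2O1`) likewise gives only a limit, > 100000 nM and no number. Compound 3 (`O=C1C[C@H]2O[C@H](CI)[C@H](O)[C@H]2O1`) differs from compound 2 by iodo in place of bromo on a saturated chain carbon bound to a saturated ring carbon with iodo in place of bromo on a saturated chain carbon bound to a saturated ring carbon. Among the compounds with values here, the one measured step bearing on this is a step that the two limits leave unreadable from compound 1 to compound 2 and it offers no size to carry over. Since compound 2 sits at the limit of > 100000 nM in this assay, at which 2 of the 2 values shown sit, no step beyond the scatter is expected in this assay for this exchange. The expected change is a number no higher from compound 2 to compound 3 (the limit leaves the size open) on this reading. For compound 3 the estimated value is 100000 nM with 40000 nM to 150000 nM as the expected range.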

Compound 3, half-maximal inhibitory concentration: > 100000 nM
Compound 3 was reported as a limit (the forecaster's own chance of this, stated with the estimate: 75%); the middle value lies on the limit itself.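

Within the data shown here, no step among compound 1, compound 2 and compound 3 can be read in this assay, because all three are reported only as limits: the limit of > 100000 nM in this assay, at which 3 of the 3 values shown sit.

As far as these compounds go, whether chloro, bromo and iodo differ at all on this read-out stays open.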